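A few compounds are considered here, and "the series" means these few. Any claim that something is new, unique, unknown or untested is made for them only; others in the source may bear on it.

Working notes on a small urea series built on one shared core. In a functional assay on NCI-H226 cells (Homo sapiens) for inhibition, read by MTT assay, with a stated time of 48 h, tested at 10 uM (on this read-out lower numbers stand for less inhibition and higher numbers for more inhibition at the one concentration tested (going by the name of the read-out)), compound 1 `CCc1ccc(Nc2cc(NC(=O)Nc3cc(OC)cc(OC)c3)ncn2)cc1` gives 50.1%, and compound 2 `COc1cc(NC(=O)Nc2cc(Nc3cc(C(F)(F)F)ccc3OC)ncn2)cc(OC)c1` gives 60%. For the measured compounds named here, of the two numbers measured so far, compound 1 holds the lower one, yet its gap to compound 2 lies within the scatter of repeated measurements of this kind, so the two read as alike and no ordering between them is claimed. Compound 3 `COc1cc(NC(=O)Nc2cc(Nc3ccc(Br)cc3OC)ncn2)cc(OC)c1` is still to be measured. Set against compound 1 the change is 4-bromo-2-methoxyphenyl in place of 4-ethylphenyl on a nitrogen on an aromatic ring. Going by the values given here, no step between two measured compounds isolates this change on its own; the only guidance is that compound 2, which likewise carries a different group on that nitrogen than compound 1, comes out close to compound 1 in this assay. On that basis the step of a number 6.9 percentage points higher from compound 1 to compound 3 (within the scatter) is expected to be small, upward if anything, and not clearly beyond the scatter. Compound 3 is accordingly estimated at 57%, with the likely range running from 40% to 74%.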

Compound 3, a percentage reported as inhibition, at one concentration (the size of the read-out at that concentration, not a potency): 25.7%
The estimate for compound 3 lay 31.3 percentage points above the measured number, outside the stated range (below it).
By their numbers in this assay, from the lowest: compound 3; then compounds 1 and 2 (each within the scatter of the next).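

In this assay, 4-bromo-2-methoxyphenyl in place of 4-ethylphenyl on a nitrogen on an aromatic ring gives a number 24.4 percentage points lower from compound 1 to compound 3 (beyond the scatter), which shows that the read-out does respond to the group at this position. Compound 2, which carries a different group on the same nitrogen, gives 60%, so replacing 4-ethylphenyl does not in itself go with a lower number, and the outcome depends on which group enters. Nothing available here explains the lower number for compound 3.

The bromine and the methoxy group enter together in this change, so the compounds shown leave open how much of the step belongs to either one, a question that a 4-bromophenyl or a 2-methoxyphenyl group on the same nitrogen would address. Also open, on these data alone, is how far the read-out at this position extends beyond these aromatic groups, for example with an amine or a carboxylic acid on the ring, or with a longer chain in place of the ethyl group of compound 1.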